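Aryl on the piperazine nitrogen substituent

The compounds below may be only part of what the source reports. "The series", "measured", "known", "first", "only" and "open" are said of these compounds alone.

Measured compounds:
compound 1 `c1coc(CN2CCN(CCCc3c[nH]c4ccc(-n5cnnc5)cc34)CC2)c1` gives 18 nM in an assay on CHO cells for displacement of a labelled ligand from 5-hydroxytryptamine receptor 1B (Homo sapiens); a higher number here means a weaker inhibitor, a lower number a stronger inhibitor
compound 2 `CN1CCN(CCCc2c[nH]c3ccc(-n4cnnc4)cc23)CC1` gives 309 nM in this assay

Compound 2 stands at the higher of the two numbers in this assay; its nearest neighbour is compound 1, separated by a 17-fold higher number from compound 1 to compound 2 (1.23 log units; beyond the scatter).

The step to compound 3 `c1ccc(CCCN2CCN(CCCc3c[nH]c4ccc(-n5cnnc5)cc34)CC2)cc1` is phenethyl in place of hydrogen on a saturated chain carbon bound to an amine nitrogen in a ring. For the measured compounds named here, the only measured step that bears on it runs in the opposite direction: a 17-fold higher number from compound 1 to compound 2 (1.23 log units; beyond the scatter), where an aromatic ring was taken off the chain carbon bound to the amine nitrogen in the ring. Restoring an aromatic ring at the same place, now as part of a three-carbon chain rather than a one-carbon link, is expected to move the number back down in this assay, though the chain and the ring type are not those of compound 1, so the full return is not assured.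

Compound 3 is therefore expected to give about 30 nM in this assay, within 8 nM to 110 nM, an expected step of a 10-fold lower number from compound 2 to compound 3 (1.01 log units; beyond the scatter).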

Compound 3, half-maximal inhibitory concentration: 85 nM
Compound 3: middle estimate off by 2.8-fold (0.45 log units), on the low side; low and high end bracket the measured number.
By their numbers in this assay, from the lowest: compound 1; then compound 3; then compound 2.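

In this assay, phenethyl in place of hydrogen on a saturated chain carbon bound to an amine nitrogen in a ring gives a 3.6-fold lower number from compound 2 to compound 3 (0.56 log units; beyond the scatter) and so shows that the fall in the number on adding a ring-bearing group at this place is not confined to furan-2-yl, with compound 1 and compound 3 both lying lower than compound 2. The two ring-bearing groups are not interchangeable, however: phenethyl in place of furan-2-yl gives a 4.7-fold higher number from compound 1 to compound 3 (0.67 log units; beyond the scatter) and recovers only part of the ground that separates compound 2 from compound 1. Nothing available explains the gap between the two groups.

Compound 1 and compound 3 differ in both the ring and the chain that carries it, so the step between them cannot be assigned to either change alone. Benzyl at this place would put a carbon-only aromatic ring on the link of compound 1, and 3-(furan-2-yl)propyl would put the furan on the chain of compound 3, so that the two contributions could be read apart.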